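The source may hold more compounds than are shown below. What is called first, only, known or untested is meant among the compounds shown, and "the series" means these compounds.

Going by the values given here, compound 2, with the structure `COc1cc2c(cc1OC)CN(S(=O)(=O)c1ccc(-n3cc(COc4ccccc4)nn3)cc1)CC2`, sits at the upper end of the two numbers measured so far in a functional assay on HepG2 cells (Homo sapiens) for cytotoxicity, read by MTT assay, with a stated time of 48 h (a higher number here means a weaker inhibitor, a lower number a stronger inhibitor), where compound 2 gives 2570 nM. Among the compounds with values here, its only measured neighbour is compound 1, `COc1cc2c(cc1OC)CN(S(=O)(=O)c1ccc(-n3cc(COc4ccc(C)cc4)nn3)cc1)CC2`, which in this assay gives 560 nM. Within the data shown here, the single step between these two, a 4.6-fold higher number from compound 1 to compound 2 (0.66 log units; beyond the scatter), shows that a small group on the outer ring can move the number well beyond the scatter.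

Compound 3, `COc1cc2c(cc1OC)CN(S(=O)(=O)c1ccc(-n3cc(COc4cc(C=O)ccc4OC)nn3)cc1)CC2`, is reached from compound 2 by the change (5-formyl-2-methoxyphenyl in place of phenyl on an oxygen on a saturated carbon). Among the measured compounds shown here, the one step available bears on it only loosely: it shows that a bare phenyl gives the higher number and a substituted phenyl the lower one, but the groups entering here are not the methyl that was removed. A step downward of moderate size is therefore expected in this assay, with wide uncertainty, as a 2.3-fold lower number from compound 2 to compound 3 (0.37 log units; beyond the scatter). Compound 3 is estimated to give about 1100 nM, most likely between 300 nM and 3500 nM.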

Compound 3, half-maximal inhibitory concentration: 41400 nM
The estimate for compound 3 lay 38-fold (1.58 log units) below the measured number; measured number outside the range, above it.
By their numbers in this assay, from the lowest: compound 1; then compound 2; then compound 3.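

In this assay, the outer ring on the oxygen turns out to be far more sensitive than the methyl step suggested: 5-formyl-2-methoxyphenyl in place of phenyl gives a 16-fold higher number from compound 2 to compound 3 (1.21 log units; beyond the scatter), and the same group in place of 4-methylphenyl gives a 74-fold higher number from compound 1 to compound 3 (1.87 log units; beyond the scatter). Substitution on this ring therefore has no single direction, since the methyl of compound 1 goes with a lower number than the bare phenyl of compound 2, while the larger group of compound 3 goes with a much higher one. Nothing at hand explains why this group has so large an effect on the number.

The entering group brings a formyl and a methoxy together, so the compounds shown cannot tell whether one of them alone accounts for the rise, or whether the step needs both. A phenyl ring bearing only the methoxy or only the formyl would separate the two, and a carboxylic acid or an amine in place of the formyl would show whether that part of the group matters.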